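This account rests on a few compounds, and the source may have more. Where it says the series, first, only, none or still open, it means among the compounds named here.

Compound 3 `CCCCCCCCS(=O)(=O)Nc1ccc(-c2ccccc2OC)cc1C(=O)O` stands at the weak end of the three measured compounds: in an assay on mitochondria (strain BALB/c) for inhibition of glycerol-3-phosphate acyltransferase 1, mitochondrial (Mus musculus), read by scintillation counting, with a stated time of 10 min (on this read-out higher numbers stand for weaker inhibition and lower numbers for stronger inhibition), compound 3 gives 27600 nM, the highest number in the set. Compound 1 `CCCCCCCCS(=O)(=O)Nc1ccc(-c2ccc(CCCC)cc2)cc1C(=O)O` gives 9000 nM in this assay, and compound 2 `CCCCCCCCS(=O)(=O)Nc1ccc(-c2ccccc2-c2ccccc2)cc1C(=O)O` gives 10100 nM in this assay. The two measured steps both lead to compound 3 and both raise the number: a 3.1-fold higher number from compound 1 to compound 3 (0.49 log units; beyond the scatter) and a 2.7-fold higher number from compound 2 to compound 3 (0.44 log units; beyond the scatter), each beyond the scatter but modest.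

Compound 4 `CCCCCCCCS(=O)(=O)Nc1ccc(-c2cccc(F)c2)cc1C(=O)O` is reached from compound 3 by the change (3-fluorophenyl in place of 2-methoxyphenyl on an aromatic carbon). For the measured compounds named here, no measured step swaps a 2-methoxyphenyl for a 3-fluorophenyl, so only the general picture bears on it: whenever the 2-methoxyphenyl of compound 3 was exchanged for another aryl group, the number fell by a modest amount. On that ground compound 4 is expected to move in the same direction, by an estimated 1.8-fold lower number from compound 3 to compound 4 (0.26 log units; within the scatter) in this assay. Compound 4 is therefore estimated at 15000 nM in this assay, with a range from 6000 nM to 35000 nM.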

Compound 4, half-maximal inhibitory concentration: 37600 nM
Beside the measured number, compound 4's estimate is 2.5-fold (0.40 log units) below it; the measured number lies above the stated range.
By their numbers in this assay, from the lowest: compounds 1 and 2 (each within the scatter of the next); then compounds 3 and 4 (each within the scatter of the next).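

In this assay, the 3-fluorophenyl in place of the 2-methoxyphenyl gives a 1.4-fold higher number from compound 3 to compound 4 (0.13 log units; within the scatter) and so leaves compound 3 and compound 4 unresolved from each other. The earlier picture, in which both other aryl groups gave lower numbers than the 2-methoxyphenyl, therefore does not extend to the 3-fluorophenyl, and compound 4 is the exception to it. The 4-butylphenyl of compound 1 keeps its advantage, with a 4.2-fold higher number from compound 1 to compound 4 (0.62 log units; beyond the scatter) as the step, so that advantage is not peculiar to the comparison with the 2-methoxyphenyl, though no measured property accounts for this result.

The compounds shown leave open whether an aminophenyl or a hydroxyphenyl group at this position would fall with compound 1 or with compound 3 and compound 4. They also leave open whether a chain longer than the butyl of compound 1 would lower the number further.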